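This account rests on a few compounds, and the source may have more. Where it says the series, first, only, none or still open, it means among the compounds named here.

In a functional assay on VCaP cells (Homo sapiens) for antiproliferative activity (a lower number here means a stronger inhibitor, a higher number a weaker inhibitor), compound 1 `CC(O)(C[S+]([O-])c1ccc(C(F)(F)F)cn1)C(=O)Nc1ccc([N+](=O)[O-])cc1C(F)(F)F` gives > 100000 nM; > 100000 nM (2 entries). Compound 2 `CC(O)(C[S+]([O-])c1ccc(F)cc1F)C(=O)Nc1ccc([N+](=O)[O-])cc1C(F)(F)F` gives > 100000 nM in this assay, a limit of the assay rather than a number, so compound 2 stands at the limit of > 100000 nM in this assay, at which 1 of the 2 values shown sits, with one further entry that also carries no single number. Compound 3 `CC(O)(C[S+]([O-])c1ccc(C(F)(F)F)cc1)C(=O)Nc1ccc([N+](=O)[O-])cc1C(F)(F)F` differs from compound 2 by 4-(trifluoromethyl)phenyl in place of 2,4-difluorophenyl on a sulfur. Among the measured compounds shown here, no step between measured compounds is available to set the size of this change, and nothing in the two limits points in either direction. Compound 3 is therefore expected to remain at or near that limit, estimated at 100000 nM with a range from 30000 nM to 300000 nM. The expected step of a number no higher from compound 2 to compound 3 (the limit leaves the size open) is none beyond the scatter.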

Compound 3, half-maximal inhibitory concentration: 24200 nM
Estimate against measurement, compound 3: 4.1-fold (0.62 log units) above, outside the stated range (below it).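

In this assay, 4-(trifluoromethyl)phenyl in place of 2,4-difluorophenyl on a sulfur gives an at least 4.1-fold lower number from compound 2 to compound 3 (0.61 log units; beyond the scatter). This shows that the group at this place can bring a compound off the limit of the assay, which compounds 1 and 2 alone did not show. Compound 2 has only a limit, so the full size of the step stays open: the limit of > 100000 nM in this assay, at which 1 of the 3 values shown sits.

The compounds shown leave open whether the trifluoromethyl group itself or the loss of the two fluorines carries the step. They also leave open how a nitrile, a chlorine or an amine on this phenyl ring would read.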